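The compounds below may be only part of what the source reports. "The series", "measured", "known", "first", "only" and "open" are said of these compounds alone.

Compound 1 `COc1ccc(S(=O)(=O)N2CCc3cccc(-c4cccnc4)c32)cc1` is the starting point of this account. In a functional assay on HT-29 cells (Homo sapiens) for inhibition, with a stated time of 72 h (on this read-out higher numbers stand for weaker inhibition and lower numbers for stronger inhibition), compound 1 gives 76.3 nM, the second highest of the three numbers in hand: its nearest neighbour is compound 3 `COc1ccc(S(=O)(=O)N2CCc3cccc(-c4ccc(F)nc4)c32)cc1`, which gives 109 nM, and its furthest is compound 2 `COc1ccc(S(=O)(=O)N2CCc3cccc(-c4ccc(C#N)cc4)c32)cc1`, which gives 24.2 nM. Against compound 3 the difference is a 1.4-fold higher number from compound 1 to compound 3 (0.15 log units; within the scatter); against compound 2 it is a 3.2-fold lower number from compound 1 to compound 2 (0.50 log units; beyond the scatter), and between those two compounds the difference is a 4.5-fold higher number from compound 2 to compound 3 (0.65 log units; beyond the scatter). The new compound 4 `COc1ccc(S(=O)(=O)N2CCc3cccc(-c4cccs4)c32)cc1` changes the aromatic group itself: thiophen-2-yl in place of pyridin-3-yl on an aromatic carbon. Within the data shown here, the only measured step that swaps the whole aromatic group is the one from compound 1 to compound 2, which was a modest one, while the other two steps concern only a fluoro on the pyridine; none of them involves thiophen-2-yl, so the direction in this assay cannot be read from them. Compound 4 is therefore expected to lie close to compound 1, with a step of a 1.1-fold lower number from compound 1 to compound 4 (0.04 log units; within the scatter), within a wide range. The estimate for compound 4 is 70 nM, between 25 nM and 200 nM.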

Compound 4, half-maximal inhibitory concentration: 200 nM
Compound 4: the middle estimate sits 2.9-fold (0.46 log units) below what was measured; the measured number falls inside the stated range.
By their numbers in this assay, from the lowest: compound 2; then compounds 1, 3 and 4 (each within the scatter of the next, the first and the last beyond it).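

In this assay the five-membered thiophen-2-yl moves the number up at this aromatic carbon, with a 2.6-fold higher number from compound 1 to compound 4 (0.42 log units; beyond the scatter). A swap of the whole aromatic group here can therefore go in either direction, since the six-membered 4-cyanophenyl went the other way, with a 3.2-fold lower number from compound 1 to compound 2 (0.50 log units; beyond the scatter). Against the remaining groups the result is a 1.8-fold higher number from compound 3 to compound 4 (0.26 log units; within the scatter), which leaves thiophen-2-yl and 6-fluoropyridin-3-yl level, and an 8.3-fold higher number from compound 2 to compound 4 (0.92 log units; beyond the scatter), the widest step among these compounds.

The compounds shown offer no measured reason for any of these steps. From the compounds shown here alone, it also stays open whether the nitrile itself or the phenyl ring carries the gain in compound 2, and how an amine or a carboxylic acid on the aromatic group would read at this position.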